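A few compounds are considered here, and "the series" means these few. Any claim that something is new, unique, unknown or untested is made for them only; others in the source may bear on it.

Among the measured compounds shown here, in an in vitro functional assay on HEK285-7 cells for antagonist activity at prostaglandin D2 receptor 2 (Homo sapiens), read by BRET and beta-arrestin recruitment (on this read-out lower numbers stand for stronger inhibition and higher numbers for weaker inhibition), compound 2 `O=C(O)Cc1sc(Cc2ccccc2)nc1-c1ccc(F)cc1` gives 180 nM, the lowest of the two numbers measured so far. For the measured compounds named here, its nearest neighbour, compound 1 `O=C(O)Cc1sc(-c2ccccc2)nc1-c1ccc(F)cc1`, gives 860 nM in this assay; the step from a 4.8-fold lower number from compound 1 to compound 2 (0.68 log units; beyond the scatter) is the only measured step, and it turns on exchanging a phenyl for a benzyl on an aromatic carbon. Compound 3 `O=C(O)Cc1sc(Cc2ccccc2Br)nc1-c1ccc(F)cc1` carries the change (bromo in place of hydrogen on an aromatic carbon), a bromo in place of hydrogen on an aromatic carbon of the six-membered carbon-only ring, ortho to a large group, so that benzyl becomes 2-bromobenzyl. Going by the values given here, no measured step touches this kind of substitution: the benzyl step speaks to the linker, not to a halogen on the outer ring. The expectation for compound 3 is therefore a step of a 1.2-fold lower number from compound 2 to compound 3 (0.08 log units; within the scatter) in this assay, small and possibly within the scatter, with compound 3 estimated at 150 nM (between 55 nM and 420 nM).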

Compound 3, half-maximal inhibitory concentration: > 100000 nM
Compound 3 was reported as a limit; the forecaster's own chance of this, stated with the estimate: 3%; middle value at least 660-fold (2.82 log units) from the limit.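

Among the compounds shown here, on this outer ring, a position that the earlier compounds left untouched proved highly sensitive: a single bromo on an aromatic carbon of the six-membered aromatic ring of carbon only, ortho to a large group, gives an at least 550-fold higher number from compound 2 to compound 3 (2.74 log units; beyond the scatter) in this assay. The change also cancels the gain seen on going from phenyl to benzyl, since 2-bromobenzyl in place of phenyl gives an at least 110-fold higher number from compound 1 to compound 3 (2.06 log units; beyond the scatter). The reading for compound 3 is a limit of the assay and not a number: the limit of > 100000 nM in this assay, at which 1 of the 3 values shown sits.

The compounds shown do not tell whether the loss belongs to bromo itself or to this place on the ring, since a fluoro or methyl here, or a bromo on another carbon of the ring, is not among them. From the compounds shown here alone, the true size of both steps also remains open.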